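A few compounds are considered here, and "the series" means these few. Any claim that something is new, unique, unknown or untested is made for them only; others in the source may bear on it.

Measured in a physicochemical assay for solubility, read by HPLC, measured as kinetic solubility; a higher number here means a more soluble compound, a lower number a less soluble compound:
- compound 1 `CC1(COCc2ccc(OCc3ccccc3)cc2)Cn2cc([N+](=O)[O-])nc2S1`: 1.2 ug/mL
- compound 2 `O=[N+]([O-])c1cn2c(n1)[S+]([O-])CC(OCc1ccc(OCc3ccccc3)cc1)C2`: 5.4 ug/mL
- compound 3 `O=[N+]([O-])c1cn2c(n1)[S@+]([O-])C[C@@H](OCc1ccc(OC(F)(F)F)cc1)C2`: 106 ug/mL

Compound 3 gives the highest of the three numbers, and its gaps to the other two lie beyond the scatter. Compound 4 `O=[N+]([O-])c1cn2c(n1)[S+]([O-])CC(OCc1ccc(OC(F)(F)F)cc1)C2` differs from it only in how its structure is drawn: the two compounds have the same atoms and bonds; at least one stereo element is drawn with a configuration in one of them and without one in the other: 2 of 2 stereo elements differ; a stereocentre at a sulfur is drawn R in compound 3 and without a configuration in compound 4; a stereocentre at a saturated ring carbon is drawn S in compound 3 and without a configuration in compound 4. Within the data shown here, no pair of measured compounds shows a change of this kind, so the data give no direct guide to its size. With atoms and bonds unchanged, no step beyond the scatter is expected in this assay, so the expectation stays close to compound 3 at 106 ug/mL. The estimated change is a 1.2-fold lower number from compound 3 to compound 4 (0.07 log units; within the scatter). For compound 4 the estimate is 90 ug/mL, with an expected range of 35 ug/mL to 190 ug/mL.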

Compound 4, solubility: 39 ug/mL
For compound 4 the middle estimate is 2.3-fold (0.36 log units) above the measured one; measured number inside the range.
By their numbers in this assay, from the lowest: compound 1; then compound 2; then compound 4; then compound 3.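

In this assay, among these compounds, no earlier pair shared the same atoms and bonds. Now such a pair shows a 2.7-fold lower number from compound 3 to compound 4 (0.43 log units; beyond the scatter), and the only recorded difference is this: the fact that one of compounds 3 and 4 is drawn with a defined configuration and the other without, at the place where they differ. Swapping the group on the oxygen on the aromatic ring, with trifluoromethyl in place of benzyl, gives a 7.2-fold higher number from compound 2 to compound 4 (0.86 log units; beyond the scatter), the first step here that isolates this change. Still open, from the compounds shown here alone, is how a methyl, a nitrile or an amine would compare with trifluoromethyl on that oxygen. Also open, going by these compounds, is whether another pair with the same change in drawing would show a similar step.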